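A few compounds are considered here, and "the series" means these few. Any claim that something is new, unique, unknown or untested is made for them only; others in the source may bear on it.

In a physicochemical assay for lipophilicity (a lower number here means a more polar compound, a higher number a more lipophilic compound), compound 1 `Cc1cccc(C2=NC(c3ccccc3)CO2)c1` gives 4.11, within the scatter of compound 3 `CCSc1ccccc1C1=NC(c2ccccc2)CO1` at 4.04. Compound 2 `COc1ccccc1C1=NC(c2ccccc2)CO1`, at 3.76, lies below compound 1 by more than the scatter. Compound 4 `Clc1cccc(C2=NC(c3ccccc3)CO2)c1` differs from compound 1 by chloro in place of methyl on an aromatic carbon, meta to a large group. Among the compounds with values here, no measured step makes this exchange. Within the data shown here, the one step available, a number 0.28 log units higher from compound 2 to compound 3 (within the scatter), puts ethylsulfanyl in place of methoxy on an aromatic carbon, stays within the scatter and offers only a loose guide. The estimated change is a small upward one within the scatter, a number 0.09 log units higher from compound 1 to compound 4 (within the scatter). Compound 4 is therefore expected at 4.2, with an estimated range from 3.9 to 4.5.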

Compound 4, partition coefficient: 4.44
Estimate against measurement, compound 4: 0.24 log units below; the range from low to high includes it.
By their numbers in this assay, from the lowest: compounds 2, 3 and 1 (each within the scatter of the next, the first and the last beyond it); then compound 4.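

In this assay, chloro in place of methyl on an aromatic carbon, meta to a large group, comes with a step of its own (a number 0.33 log units higher from compound 1 to compound 4 (beyond the scatter)). Of the two single-place steps shown, this is the one that lies beyond the scatter, while a number 0.28 log units higher from compound 2 to compound 3 (within the scatter) stays within it. No measured evidence here accounts for the size of this step.

The compounds shown leave open how an amine or a carboxylic acid at this place would compare with chloro and methyl. They also leave open whether the same exchange gives a similar step elsewhere on the shared core.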